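This account rests on a few compounds, and the source may have more. Where it says the series, first, only, none or still open, it means among the compounds named here.

Measured so far:
- compound 1, `Cc1cc(C(=O)N2CCCCc3ccccc32)ccc1CNC(=O)N1C[C@H](O)C[C@H]1C(=O)N(C)C`: 41 nM
- compound 2, `CO[C@@H]1C[C@@H](C(=O)N(C)C)N(C(=O)NCc2ccc(C(=O)N3CCCCc4ccccc43)cc2C)C1`: 65 nM

Both numbers come from a functional assay on HEK293 cells for agonist activity at Vasopressin V2 receptor (Rattus norvegicus), read by a luciferase reporter and cAMP accumulation; on this read-out lower numbers stand for an effect already at smaller amounts and higher numbers for an effect only at larger amounts of compound. Among the measured compounds shown here, compound 2 and compound 1 sit close together on this read-out: the only step measured, a 1.6-fold higher number from compound 1 to compound 2 (0.20 log units; within the scatter), shows that replacing the hydrogen on the ring oxygen of compound 1 by a methyl left the activity essentially unchanged.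

Compound 3, `CCO[C@@H]1C[C@@H](C(=O)N(C)C)N(C(=O)NCc2ccc(C(=O)N3CCCCc4ccccc43)cc2C)C1`, has not yet been measured in this assay. It differs from compound 2 by methyl in place of hydrogen on a saturated chain carbon bound to an oxygen on a saturated carbon, which read one bond further out is methyl to ethyl, or methoxy to ethoxy. For the measured compounds named here, the one step that bears on this change is the step from compound 1 to compound 2, where the same oxygen first received its methyl and the number moved only within the scatter. Building that methyl out by one further carbon is a change of the same kind at the same place, so no step beyond the scatter is expected in this assay for compound 3, with at most a small drift toward a higher number. The expected step is a 1.3-fold higher number from compound 2 to compound 3 (0.12 log units; within the scatter). On that basis compound 3 is estimated at 85 nM, with a range from 35 nM to 210 nM.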

Compound 3, half-maximal effective concentration: 15 nM
For compound 3 the middle estimate is 5.7-fold (0.75 log units) above the measured one; the whole stated range lies above it.
By their numbers in this assay, from the lowest: compound 3; then compounds 1 and 2 (each within the scatter of the next).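

In this assay the oxygen on the saturated carbon proves sensitive to what it carries: one added carbon gives a 4.3-fold lower number from compound 2 to compound 3 (0.64 log units; beyond the scatter) even though the earlier change at the same oxygen, from hydrogen to methyl, stayed within the scatter. Among the compounds shown here, measured against the free hydrogen, the ethyl group gives a 2.7-fold lower number from compound 1 to compound 3 (0.44 log units; beyond the scatter) as well, so across these three compounds the number does not follow the carbon count evenly: the first carbon produces no step beyond the scatter, and only the second does. Nothing in the available data explains this shift.

On these data alone, whether a longer chain such as propyl, or a branched one such as isopropyl, on this oxygen would lower the number further or bring it back toward that of compound 2 remains open. Also open, as far as these compounds go, is whether the lower number depends on a plain carbon chain at all, a question that an amine or a carboxylic acid at the end of the ethyl chain could help to answer.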